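A few compounds are considered here, and "the series" means these few. Any claim that something is new, unique, unknown or untested is made for them only; others in the source may bear on it.

In an ADME assay on J774 cells (Mus musculus) for cytotoxicity (a higher number here means that more compound is needed for the effect, a lower number that less compound is needed), three compounds sharing one core have been measured so far. Compound 1 `Cc1[nH]c2ccccc2c(=O)c1Br` gives > 42000 nM, which is a limit and not a number. Compound 2 `COc1ccc2[nH]c(C)c(Br)c(=O)c2c1` gives > 37300 nM, which is also a limit. Among the compounds with values here, compound 3 `Cc1ccc2[nH]c(C)c(Br)c(=O)c2c1` gives 19600 nM, the only true number among the three, so it cannot be ranked exactly against the other two.

Compound 4 `Cc1[nH]c2ccc(Br)cc2c(=O)c1Br` differs from compound 3 in a single group: bromo in place of methyl on an aromatic carbon. In words, this is bromo in place of methyl on an aromatic carbon.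

Within the data shown here, no measured step makes this exact exchange, so the evidence is indirect. Methyl in place of hydrogen on an aromatic carbon shows an at least 2.1-fold lower number from compound 1 to compound 3 (0.33 log units; beyond the scatter). Methyl in place of methoxy shows an at least 1.9-fold lower number from compound 2 to compound 3 (0.27 log units; that floor lies within the scatter). Methoxy in place of hydrogen shows a step that the two limits leave unreadable from compound 1 to compound 2. Only the first of these is a step beyond the scatter, and it is known only as a minimum.

With compound 3 at 19600 nM as the anchor, bromo is expected to behave much like the methyl it replaces. The estimate is a 1.2-fold lower number from compound 3 to compound 4 (0.09 log units; within the scatter), an expected change that stays within the scatter. Compound 4 is estimated at 16000 nM, with an expected range from 6500 nM to 40000 nM.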

Compound 4, half-maximal effective concentration: > 31500 nM
Compound 4 ended at the assay's limit; the forecaster's own chance of this, stated with the estimate: 25%; at least 1.9-fold (0.29 log units) between middle value and limit.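

In this assay, bromo in place of methyl at this position gives an at least 1.6-fold higher number from compound 3 to compound 4 (0.20 log units; that floor lies within the scatter). This shows that the position does not need to carry methyl for the compound to reach a limit, since compound 4 ends at a limit and not at a number, as compounds 1 and 2 do: the limit of > 31500 nM in this assay, at which 1 of the 4 values shown sits. Among hydrogen, methoxy, methyl and bromo on this aromatic carbon, only methyl in compound 3 gives a true number, and the steps among the other three cannot be read.

On these data alone, the true number of compound 4 remains unknown, so it stays open whether bromo in place of methyl moves the number beyond the scatter, or whether methyl truly differs from the other three groups. As far as these compounds go, it is also open how an amine, a carboxylic acid or a longer chain such as ethyl on this aromatic carbon would compare with methyl in this assay.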